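Acrylamide cinnamanilides: methoxy count on the anilide ring

This account rests on a few compounds, and the source may have more. Where it says the series, first, only, none or still open, it means among the compounds named here.

Measured compounds:
- compound 1, `C=C(Br)C(=O)Nc1cccc(/C=C/C(=O)Nc2ccccc2)c1`: 16600 nM
- compound 2, `C=C(Br)C(=O)Nc1cccc(/C=C/C(=O)Nc2ccc(OC)cc2)c1`: 2300 nM
- compound 3, `C=C(Br)C(=O)Nc1cccc(/C=C/C(=O)Nc2cc(OC)cc(OC)c2)c1`: 3600 nM

All three share the same core and differ only in the substitution of the anilide ring. In a functional assay on HT-29 cells (Homo sapiens) for inhibition, read by MTT assay, with a stated time of 72 h (on this read-out lower numbers stand for stronger inhibition and higher numbers for weaker inhibition), compound 1 gives 16600 nM. The change methoxy in place of hydrogen on an aromatic carbon gives a 7.2-fold lower number from compound 1 to compound 2 (0.86 log units; beyond the scatter), so in this assay compound 2 sits at 2300 nM. Compound 3 carries two methoxy groups; its value of 3600 nM lies within the scatter of compound 2, so no order between compound 2 and compound 3 can be read, while its gap to compound 1 lies beyond the scatter. The difference between the core of compound 1 and the core of compound 3 is not broken down here.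

Compound 4, `C=C(Br)C(=O)Nc1cccc(/C=C/C(=O)Nc2cc(OC)c(OC)c(OC)c2)c1`, has not yet been measured in this assay. It differs from compound 3 by methoxy in place of hydrogen on an aromatic carbon. Among the measured compounds shown here, this is the same kind of change as the one from compound 1 to compound 2, but the place differs: in compound 4 the entering group sits ortho to two methoxy groups (2 heavy atoms each) and para to a large group, whereas in compound 2 it sits only para to a large group.

The expectation for compound 4 rests on the value of compound 3, 3600 nM, and on the step of a 7.2-fold lower number from compound 1 to compound 2 (0.86 log units; beyond the scatter), which shows that a methoxy entering this ring lowered the number once before. The expected step of a 1.4-fold lower number from compound 3 to compound 4 (0.16 log units; within the scatter) is kept smaller than that earlier step, since the step from compound 2 to compound 3 did not go beyond the scatter. Compound 4 is therefore estimated at 2500 nM, expected between 800 nM and 8000 nM.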

Compound 4, half-maximal inhibitory concentration: 2300 nM
Compound 4: the middle estimate sits 1.1-fold (0.04 log units) above what was measured; the measured number falls inside the stated range.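

In this assay, methoxy in place of hydrogen on an aromatic carbon, ortho to two methoxy groups and para to a large group, gives a 1.6-fold lower number from compound 3 to compound 4 (0.19 log units; within the scatter), so no order between compound 3 and compound 4 can be read. The change therefore does not carry over at the same size from one core to the other, and its clear effect on the unsubstituted anilide ring is not repeated on the dimethoxy core: the same change on two cores in this assay, a 7.2-fold lower number (0.86 log units; beyond the scatter) from compound 1 to compound 2 and a 1.6-fold lower number (0.19 log units; within the scatter) from compound 3 to compound 4, 4.6-fold (0.66 log units) apart, beyond the scatter of two such steps. Among the compounds shown here, this rests on only two steps and does not show why they differ, nor can it separate the influence of the core from that of the place, since the entering methoxy in compound 2 sits only para to a large group, whereas in compound 4 it also sits ortho to two methoxy groups.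

The compounds shown leave open whether a group other than methoxy on the anilide ring, such as an amine, a hydroxy group or a carboxylic acid, would give a step beyond the scatter on either core. They also leave open whether the same steps would appear with a different group in place of the bromine on the shared core.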